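Moving two fluorines on the amide's phenyl group

This account rests on a few compounds, and the source may have more. Where it says the series, first, only, none or still open, it means among the compounds named here.

In a functional assay on HT-29 cells (Homo sapiens) for cytotoxicity, read by MTT assay, with a stated time of 72 h (on this read-out higher numbers stand for weaker inhibition and lower numbers for stronger inhibition), compound 1 `O=C(CN1CCN(c2nnc(Cc3ccncc3)c3ccccc23)CC1)Nc1cccc(Br)c1` gives 1350 nM and compound 2 `O=C(CN1CCN(c2nnc(Cc3ccncc3)c3ccccc23)CC1)Nc1c(F)cccc1F` gives 28700 nM, the higher of the two numbers and so the weaker inhibition. Among the measured compounds shown here, the one measured step, a 21-fold higher number from compound 1 to compound 2 (1.33 log units; beyond the scatter), put 2,6-difluorophenyl in place of 3-bromophenyl on an amide-type nitrogen. Compound 3 `O=C(CN1CCN(c2nnc(Cc3ccncc3)c3ccccc23)CC1)Nc1ccc(F)c(F)c1` has the same atoms as compound 2, joined differently: 3,4-difluorophenyl in place of 2,6-difluorophenyl on an amide-type nitrogen. For the measured compounds named here, only that single large step bears on this change, which makes it thin support. By name, 3,4-difluorophenyl reads closer to the 3-bromophenyl of compound 1, at 1350 nM, than 2,6-difluorophenyl does. A large move to a lower number is therefore expected in this assay, recovering most of that gap. The estimated change is a 7.2-fold lower number from compound 2 to compound 3 (0.86 log units; beyond the scatter). For compound 3 the expected value is 4000 nM, with an estimated range of 1200 nM to 17000 nM.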

Compound 3, half-maximal inhibitory concentration: 2320 nM
Estimate against measurement, compound 3: 1.7-fold (0.24 log units) above; low and high end bracket the measured number.
By their numbers in this assay, from the lowest: compounds 1 and 3 (each within the scatter of the next); then compound 2.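

Compound 2 and compound 3 carry the same atoms, so the large step in this assay, a 12-fold lower number from compound 2 to compound 3 (1.09 log units; beyond the scatter), shows that this position on the amide-type nitrogen responds to where the two fluorines sit on the phenyl ring, not only to which atoms are present. The second step, a 1.7-fold higher number from compound 1 to compound 3 (0.24 log units; within the scatter), shows that 3,4-difluorophenyl and 3-bromophenyl cannot be told apart here, so 2,6-difluorophenyl alone stands apart among these three compounds. No measurement at hand explains why the arrangement of the fluorines matters so much.

Still open, going by these compounds, is how a plain phenyl group, or a phenyl carrying a methoxy group or a nitrile, would compare at this position. Also open, on these data alone, is whether the same order would hold with a longer chain between the amide-type nitrogen and the ring.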